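This account rests on a few compounds, and the source may have more. Where it says the series, first, only, none or still open, it means among the compounds named here.

Measured so far in a functional assay on HUVEC cells (Homo sapiens) for inhibition, tested at 10 ug/mL; a lower number here means a weaker effect, a higher number a stronger effect of the compound at the concentration tested:
- compound 1, `COc1cc(/C=C/C(=O)c2cccc(NC(=O)c3c(Cl)cccc3Cl)c2)ccc1O`: 99%
- compound 2, `COc1cc(/C=C/C(=O)c2cccc(NC(=O)c3ccco3)c2)ccc1O`: 100%
- compound 3, `COc1cc(/C=C/C(=O)c2cccc(NC(=O)c3ccc(Cl)c(Cl)c3)c2)ccc1O`: 45%

Compound 1 stands second highest of the three; its nearest neighbour is compound 2, a number 1 percentage points higher from compound 1 to compound 2 (within the scatter), and the furthest is compound 3, a number 54 percentage points lower from compound 1 to compound 3 (beyond the scatter). The step to compound 4, `COC(=O)C(=O)Nc1cccc(C(=O)/C=C/c2ccc(O)c(OC)c2)c1`, is methoxycarbonyl in place of 2,6-dichlorophenyl on a carbonyl carbon.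

For the measured compounds named here, two measured steps bear on it, both changing the group on the same carbonyl carbon: a number 1 percentage points higher from compound 1 to compound 2 (within the scatter) and a number 54 percentage points lower from compound 1 to compound 3 (beyond the scatter). Neither swaps the six-membered aromatic ring of carbon only for a group with no ring, so the direction is not settled; the number for compound 1 leaves room mainly downward. A moderate drop is therefore expected, a number 29 percentage points lower from compound 1 to compound 4 (beyond the scatter), with wide uncertainty.

Compound 4 is estimated at 70% in this assay, between 30% and 100%.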

Compound 4, a percentage reported as inhibition, at one concentration (the size of the read-out at that concentration, not a potency): 43%
Estimate against measurement, compound 4: 27 percentage points above; measured number inside the range.
By their numbers in this assay, from the lowest: compounds 4 and 3 (each within the scatter of the next); then compounds 1 and 2 (each within the scatter of the next).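

In this assay, methoxycarbonyl on the carbonyl carbon loses the high read-out seen with 2,6-dichlorophenyl (a number 56 percentage points lower from compound 1 to compound 4 (beyond the scatter)) and with furan-2-yl (a number 57 percentage points lower from compound 2 to compound 4 (beyond the scatter)). Against 3,4-dichlorophenyl it shows no separation (a number 2 percentage points lower from compound 3 to compound 4 (within the scatter)), so a group with no ring and a ring-bearing group can land at the same low level, and a ring at this place does not by itself keep the read-out high. No measured evidence accounts for these steps.

Still open, as far as these compounds go, is whether a carboxylic acid in place of methoxycarbonyl stays at the low level, and whether an unsubstituted phenyl or a thiophene reaches the high one.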